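From benzyl to cyclohexyl on an amine nitrogen

The source may hold more compounds than are shown below. What is called first, only, known or untested is meant among the compounds shown, and "the series" means these compounds.

Compound 1 `O=C1C=C(NCc2ccccc2)C(=O)c2c1nc1n2[C@H]2OC[C@@H](O)[C@H]2OC1`: > 8000 nM
Compound 2 `O=C1C(NC2CCCC2)=CC(=O)c2c1nc1n2[C@H]2OC[C@@H](O)[C@H]2OC1`: > 16000 nM

In a functional assay on ECa-109 cells for inhibition, with ECa-109 cell line (Homo sapiens) as the target, read by sulforhodamine B assay (a lower number here means a stronger inhibitor, a higher number a weaker inhibitor), compound 1 gives > 8000 nM, which is a limit and not a number. Compound 2 likewise gives only a limit, > 16000 nM. Compound 3 `O=C1C=C(NC2CCCCC2)C(=O)c2c1nc1n2[C@H]2OC[C@@H](O)[C@H]2OC1` keeps the core of compound 1 and changes one group: cyclohexyl in place of benzyl on an amine nitrogen. Compound 1 stays at its limit of > 8000 nM, so compound 3 is expected to show little inhibition too. In this assay the estimated step that the limit leaves unreadable from compound 1 to compound 3 is expected to stay within the usual scatter, with no clear direction. For compound 3 the estimated value is 11000 nM, with an expected range from 4000 nM to 30000 nM.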

Compound 3, half-maximal inhibitory concentration: > 16000 nM
Compound 3: a limit, no number; the forecaster's own chance of this, stated with the estimate: 75%; at least 1.4-fold (0.16 log units) between middle value and limit.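

For the compounds shown here, compound 1 and compound 3 both give only limits, not numbers, and no step between them can be read. The compounds shown leave open how strongly each one actually inhibits, and whether benzyl or cyclohexyl gives the stronger inhibitor.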